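The compounds below may be only part of what the source reports. "The series", "measured", "known", "first", "only" and "open" are said of these compounds alone.

Compound 1 `CCCc1cc(O)c(Cl)c(O)c1Oc1c(Cl)c(O)c(Cl)c2c1C(=O)O[C@@H]2CC`, compound 2 `CCCc1c(Cl)c(O)cc(OC)c1Oc1c(Cl)c(O)c(Cl)c2c1C(=O)O[C@@H]2CC` and compound 3 `CCCc1cc(O)cc(O)c1Oc1c(Cl)c(O)c(Cl)c2c1C(=O)O[C@@H]2CC` have been measured, while compound 4 `CCCc1cc(O)cc(OC)c1Oc1c(Cl)c(O)c(Cl)c2c1C(=O)O[C@@H]2CC` has not. In an ADME assay on MDCK cells (Canis lupus familiaris) for cytotoxicity, read by CellTiter-Glo, with a stated time of 40 h (a lower number here means that less compound is tolerated, a higher number that more compound is tolerated), compound 1 gives > 100000 nM, which is a limit of the assay. Compound 2 gives > 100000 nM in this assay, again a limit. Compound 3 gives > 100000 nM in this assay, also a limit, so its standing is known only as a bound. The change from compound 3 to compound 4 is methyl in place of hydrogen on an oxygen on an aromatic ring. Among the measured compounds shown here, the one measured step that touches compound 3 is a step that the two limits leave unreadable from compound 1 to compound 3, and the limit of > 100000 nM in this assay, at which 3 of the 3 values shown sit, leaves nothing readable. No step beyond the scatter in this assay is therefore expected in either direction, and the step is estimated as a number no higher from compound 3 to compound 4 (the limit leaves the size open). Compound 4 is expected to give 100000 nM, within 50000 nM to 300000 nM, most likely again as a limit.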

Compound 4, half-maximal cytotoxic concentration: > 100000 nM
Compound 4: only a limit was reported (the forecaster's own chance of this, stated with the estimate: 85%); the middle value sits exactly at the limit.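

In this assay, among the compounds shown here, compound 4 reads only as a limit, so no step to it from compound 2 or compound 3 can be read: the limit of > 100000 nM in this assay, at which 4 of the 4 values shown sit. As far as these compounds go, the concentration at which any of these four compounds harms the cells stays open.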